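A few compounds are considered here, and "the series" means these few. Any claim that something is new, unique, unknown or untested is made for them only; others in the source may bear on it.

Measured so far:
compound 1 `CCCCn1cc(COc2cc(O)c3c(c2)O[C@H](c2ccc(OC)c(O)c2)C/C3=N\O)nn1` with 8900 nM
compound 2 `COc1ccc([C@@H]2CC(=O)c3c(O)cc(OCc4cn(Cc5ccc(C)cc5)nn4)cc3O2)cc1O` with 16800 nM
compound 3 `COc1ccc([C@@H]2CC(=O)c3c(O)cc(OCc4cn(C5CCCC5)nn4)cc3O2)cc1O` with 10500 nM

In a functional assay on RAW264.7 cells (Mus musculus) for inhibition, read by Griess assay, with stated times of 2 h and 24 h (on this read-out higher numbers stand for weaker inhibition and lower numbers for stronger inhibition), compound 3 stands second highest of the three numbers; its gaps to compound 1 and to compound 2 are both within the scatter, so no order among the three can be drawn. Compound 4 `COc1ccc([C@@H]2CC(=O)c3c(O)cc(OCc4cn(CCCO)nn4)cc3O2)cc1O` is not yet measured. It differs from compound 3 by 3-hydroxypropyl in place of cyclopentyl on an aromatic nitrogen. Within the data shown here, the one measured step at the same aromatic nitrogen, a 1.6-fold lower number from compound 2 to compound 3 (0.20 log units; within the scatter), stayed within the scatter, and no other step bears on a 3-hydroxypropyl at that place. The expectation in this assay is therefore no step beyond the scatter. For compound 4 the estimate is 10000 nM with a range of 4000 nM to 25000 nM. The expected step is a 1.1-fold lower number from compound 3 to compound 4 (0.02 log units; within the scatter).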

Compound 4, half-maximal inhibitory concentration: 16700 nM
Compound 4: the middle estimate sits 1.7-fold (0.22 log units) below what was measured, within the range that was stated.
By their numbers in this assay, from the lowest: compounds 1, 3, 4 and 2 (each within the scatter of the next).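

In this assay, 3-hydroxypropyl in place of cyclopentyl on the aromatic nitrogen gives a 1.6-fold higher number from compound 3 to compound 4 (0.20 log units; within the scatter), and 2-hydroxyethyl in place of 4-methylphenyl on the saturated chain carbon bound to that nitrogen gives a 1.0-fold lower number from compound 2 to compound 4 (0.00 log units; within the scatter). An open chain ending in a hydroxyl thus joins the two ring-bearing groups with no step beyond the scatter, so the three groups at this position cannot be ordered. From the compounds shown here alone, whether an amine or a carboxylic acid at the chain end, or a longer chain, would move the number beyond the scatter stays open. Nothing available explains these results.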